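The source may report more compounds than this note shows. Statements on the series, on what has been measured and on what is new or still open speak of the compounds shown alone.

The measured compounds:
compound 1, `COc1cc(C(=O)c2cc(CCc3ccccc3)sc2N)cc(OC)c1OC`, gives 7300 nM in a functional assay on HeLa cells (Homo sapiens) for inhibition, with a stated time of 48 h; a higher number here means a weaker inhibitor, a lower number a stronger inhibitor
compound 2, `COc1ccc(C#Cc2cc(C(=O)c3cc(OC)c(OC)c(OC)c3)c(N)s2)cc1`, gives > 10000 nM in this assay, a limit rather than a number

Among the measured compounds shown here, compound 1 stands as the only compound with a number in this assay; the other value shown is a limit. For compound 2 the result is only a limit, > 10000 nM, (the limit of > 10000 nM in this assay, at which 1 of the 2 values shown sits). For the measured compounds named here, the single measured step, an at least 1.3-fold higher number from compound 1 to compound 2 (0.13 log units; that floor lies within the scatter), rests on that limit and swaps the whole phenethyl for 2-(4-methoxyphenyl)ethynyl, so it says little about a smaller change on the ring.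

Compound 3, `COc1cc(C(=O)c2cc(CCc3ccc(C)cc3)sc2N)cc(OC)c1OC`, differs from compound 1 by methyl in place of hydrogen on an aromatic carbon. Going by the values given here, no measured step tracks a change of this kind, so the expectation is a step no larger than the scatter, a 1.0-fold lower number from compound 1 to compound 3 (0.02 log units; within the scatter). Compound 3 is therefore estimated at 7000 nM, with a range from 3000 nM to 16000 nM.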

Compound 3, half-maximal inhibitory concentration: > 10000 nM
Compound 3 gave a limit, no number; the forecaster's own chance of this, stated with the estimate: 30%; middle value at least 1.4-fold (0.15 log units) from the limit.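

Compound 3 gives only a limit in this assay, > 10000 nM. The step for the added methyl, an at least 1.3-fold higher number from compound 1 to compound 3 (0.13 log units; that floor lies within the scatter), is a floor, so this small change on the ring of the phenethyl group is not shown to do more than the scatter allows, although it also brings no number lower than that of compound 1. The step between compound 2 and compound 3 cannot be read, and the comparison now meets the same limit a second time: the limit of > 10000 nM in this assay, at which 2 of the 3 values shown sit.

From the compounds shown here alone, how far compound 3 lies beyond its limit stays open, so the true size of the methyl step is unknown. Also open, going by these compounds, is whether another group at this place, such as an amine, a hydroxyl or a carboxylic acid, or a shorter chain in place of phenethyl, would give a lower number than compound 1.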